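A few compounds are considered here, and "the series" means these few. Any claim that something is new, unique, unknown or untested is made for them only; others in the source may bear on it.

Compound 2 `CCN1CCC(NC(=O)c2nc(C(C)C)n3ccccc23)CC1` and compound 1 `CC(C)c1nc(-c2nnc(C3CCN(C4CCC4)CC3)o2)c2ccccn12` were both tested in a functional assay on CHO cells for agonist activity at 5-hydroxytryptamine receptor 4 (Homo sapiens), read by a luciferase reporter and cAMP accumulation, with a stated time of 4 h; on this read-out lower numbers stand for smaller maximal responses and higher numbers for larger maximal responses. Compound 2 gave 100%, and compound 1 gave 55%; the two values thus differ by a gap beyond the usual scatter, and compound 2 stands highest of the two numbers recorded. The two compounds differ in more than one place, so only their two values can be compared.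

Compound 3 `COCC(C)(C)CN1CCC(NC(=O)c2nc(C(C)C)n3ccccc23)CC1` has not yet been measured in this assay. It differs from compound 2 in a single place: 1-(methoxymethyl)-1-methylethyl in place of methyl on a saturated chain carbon bound to an amine nitrogen in a ring. Among the compounds with values here, no step between measured compounds is recorded for this kind of change, so the size of the expected step rests on compound 2 alone. Given compound 2 at 100%, a modest downward step is expected, possibly no larger than the scatter, with the step from compound 2 to compound 3 estimated as a number 20 percentage points lower from compound 2 to compound 3 (beyond the scatter). Compound 3 is therefore expected to reach about 80%, within a range from 50% to 105%.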

Compound 3, largest response reached (Emax), in percent of the reference or control that the assay uses: 74%
Beside the measured number, compound 3's estimate is 6 percentage points above it, within the range that was stated.
By their numbers in this assay, from the lowest: compound 1; then compound 3; then compound 2.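

In this assay, 1-(methoxymethyl)-1-methylethyl in place of methyl on a saturated chain carbon bound to an amine nitrogen in a ring gives a number 26 percentage points lower from compound 2 to compound 3 (beyond the scatter), the first step recorded at this position. The step is modest, and compound 3 keeps a clear maximal response at 74%, so this place tolerates a much larger group without losing the response. Nothing measured here accounts for the size of this step.

The compounds shown leave open which part of the entering group goes with the lower response, its branching, its length or its oxygen. A longer unbranched carbon chain, or the same branched chain ending in a hydroxyl group, would help to separate these parts.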